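This account rests on a few compounds, and the source may have more. Where it says the series, first, only, none or still open, it means among the compounds named here.

Measured so far:
compound 1 `Cc1cc(C)cc(C(=O)Nc2nc3ccc(NC(=O)CSc4ccc(Cl)cc4)cc3s2)c1`: 65100 nM
compound 2 `Cc1ccc(C(=O)Nc2nc3ccc(NC(=O)CSc4ccc(Cl)cc4)cc3s2)cc1`: 2120 nM

In a functional assay on HCT-116 cells (Homo sapiens) for antiproliferative activity, read by MTT assay, with a stated time of 72 h (on this read-out higher numbers stand for weaker inhibition and lower numbers for stronger inhibition), compound 2 has the lower of the two numbers, at 2120 nM. Compound 3 `O=C(CSc1ccc(Cl)cc1)Nc1ccc2nc(NC(=O)c3ccc4ccccc4c3)sc2c1` differs from it in one place, on a carbonyl carbon whose other neighbour is an amide-type nitrogen: naphthalen-2-yl in place of 4-methylphenyl on a carbonyl carbon. Naphthalen-2-yl thus stands in place of 4-methylphenyl.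

Among the measured compounds shown here, only one measured step bears on this place: a 31-fold lower number from compound 1 to compound 2 (1.49 log units; beyond the scatter). It shows that this assay can respond strongly to a change here, but it involves a different group. Compound 1 at 65100 nM is the only hint that more carbon in this place goes with a higher number, so a moderate rise is expected, smaller than that step. The expected change is a 2.8-fold higher number from compound 2 to compound 3 (0.45 log units; beyond the scatter). For compound 3 the estimate is 6000 nM, with an expected range of 1300 nM to 30000 nM.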

Compound 3, half-maximal inhibitory concentration: 4040 nM
Estimate against measurement, compound 3: 1.5-fold (0.17 log units) above; low and high end bracket the measured number.
By their numbers in this assay, from the lowest: compounds 2 and 3 (each within the scatter of the next); then compound 1.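

In this assay, the step to two fused aromatic rings, a 1.9-fold higher number from compound 2 to compound 3 (0.28 log units; within the scatter), lies within the usual scatter, so naphthalen-2-yl and 4-methylphenyl cannot be told apart on a carbonyl carbon here. Among the compounds shown here, the other step, a 16-fold lower number from compound 1 to compound 3 (1.21 log units; beyond the scatter), is large, which leaves 3,5-dimethylphenyl as the one group of the three that stands apart. The earlier hint that more carbon in this place goes with a higher number therefore does not hold, as compound 3 goes against it. No measurement shown explains why 3,5-dimethylphenyl differs from the other two groups.

All three groups shown are built of carbon and hydrogen only. Going by these compounds, how the number responds to a group carrying other atoms in this place, such as an amine or a carboxylic acid, stays open.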